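This account rests on a few compounds, and the source may have more. Where it says the series, first, only, none or still open, it means among the compounds named here.

Compound 1 `COc1ccc(-c2cnc(NC(=O)CCc3ccccc3)n2C)cc1`; compound 2 `COc1ccc(-c2cnc(NC(=O)c3ccc(O)cc3)n2C)cc1`.

In a toxicity assay on THP-1 cells (Homo sapiens) for inhibition (on this read-out higher numbers stand for lower toxicity in this test and lower numbers for higher toxicity in this test), compound 1 gives only a limit, > 100000 nM. Compound 2 likewise gives only a limit, > 100000 nM. Both values sit at the limit of > 100000 nM in this assay, at which 2 of the 2 values shown sit, so compound 2 stands at that limit with nothing numerical below it. Compound 3 `COc1ccc(-c2cnc(NC(=O)c3cccc(C#N)c3)n2C)cc1` differs from compound 2 by 3-cyanophenyl in place of 4-hydroxyphenyl on a carbonyl carbon. Going by the values given here, the single measured step, a step that the two limits leave unreadable from compound 1 to compound 2, touches the same carbonyl carbon but its size cannot be read. No movement beyond the scatter is therefore expected in this assay. Compound 3 is estimated at 100000 nM, between 40000 nM and 300000 nM, an expected step of a number no higher from compound 2 to compound 3 (the limit leaves the size open).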

Compound 3, half-maximal cytotoxic concentration: > 100000 nM
Compound 3: only a limit was reported (the forecaster's own chance of this, stated with the estimate: 85%); the middle value sits exactly at the limit.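

In this assay, going by these compounds alone, compound 3 gives only a limit, > 100000 nM and so no step among compound 1, compound 2 and compound 3 can be read: the limit of > 100000 nM in this assay, at which 3 of the 3 values shown sit. The compounds shown leave open whether any of these groups on the carbonyl carbon shifts the read-out of this assay at all.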